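Shortening the chain: from compound 3 to compound 4

The compounds below may be only part of what the source reports. "The series", "measured", "known", "first", "only" and "open" are said of these compounds alone.

Measured so far:
compound 1 `C/N=C(/NC#N)NCCCn1nc(-c2ccccc2)ccc1=O`: 40.5%
compound 2 `CC/N=C(\S)NCCCn1nc(-c2ccccc2)ccc1=O`: 39%
compound 3 `C/N=C(\NC#N)NCCCCn1nc(-c2ccccc2)ccc1=O`: 79%

In a functional assay on the whole organism with Rattus norvegicus as the target, at a dose of 100 mg/kg (a lower number here means less inhibition, a higher number more inhibition at the dose given (going by the name of the read-out)), compound 3 stands highest of the three numbers; compound 1 is nearest, compound 2 furthest, and both lie beyond the scatter from it. Compound 4 `N#CNC(=N)NCCCn1nc(-c2ccccc2)ccc1=O` is the next step: a group of 6 heavy atoms (2 carbon, 4 nitrogen; no ring) in place of a group of 8 heavy atoms (4 carbon, 4 nitrogen; no ring), on a saturated chain carbon, three bonds along the chain from an aromatic nitrogen. For the measured compounds named here, two measured steps bear on this, since both alter the group at the same place, on a saturated chain carbon three bonds along the chain from an aromatic nitrogen: a number 38.5 percentage points higher from compound 1 to compound 3 (beyond the scatter) and a number 40 percentage points higher from compound 2 to compound 3 (beyond the scatter). Both were large and upward toward compound 3. Compound 4 undoes a change of that kind, so a large downward step is expected, a number 37 percentage points lower from compound 3 to compound 4 (beyond the scatter). Compound 4 is therefore estimated at 42%, within a range from 25% to 60%.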

Compound 4, a percentage reported as inhibition, in the whole organism at one dose (the size of the read-out at that dose, not a potency): 33.3%
Estimate against measurement, compound 4: 8.7 percentage points above, and the stated range covers the measured number.
By their numbers in this assay, from the lowest: compounds 4, 2 and 1 (each within the scatter of the next); then compound 3.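

In this assay, the large step of a number 45.7 percentage points lower from compound 3 to compound 4 (beyond the scatter) comes with the shorter chain, and the high number of compound 3 is not kept. Among the compounds with the shorter chain, changing the group on the amine nitrogen gives only a number 7.2 percentage points lower from compound 1 to compound 4 (within the scatter) and a number 5.7 percentage points lower from compound 2 to compound 4 (within the scatter), so this position shows no clear response to those groups at this chain length. No measurement here explains the difference. From the compounds shown here alone, whether a longer chain than that of compound 3 would raise the number further remains open. So does how an amide in place of the nitrile would behave with either chain.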